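This account rests on a few compounds, and the source may have more. Where it says the series, first, only, none or still open, it means among the compounds named here.

Measured in a functional assay on MCF7 cells (Homo sapiens) for antiproliferative activity, read by MTT assay, with a stated time of 72 h (a lower number here means a stronger inhibitor, a higher number a weaker inhibitor), as follows:
- compound 1 `CC1=CC[C@H]2[C@@H]1CC=C(C)[C@@H](CCC1=C(C)CC[C@@H]3OC(C)(C)[C@@H](O)CC[C@@]13C)C2(C)C` gives > 50000 nM (a limit, not a number)
- compound 2 `CC(=O)O[C@H]1CC[C@]2(C)[C@H](CC[C@@](C)(O)[C@H]2CC[C@@H]2C(C)=CC[C@H]3[C@H](CC[C@]3(C)O)C2(C)C)OC1(C)C` gives 47900 nM (a number)

Going by the values given here, compound 2 at 47900 nM holds the only actual number, so the scale has a single anchor and no measured step exists.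

Compound 3 `CC1=CC[C@H]2[C@H](CC[C@]2(C)O)C(C)(C)[C@@H]1CC[C@H]1[C@]2(C)CC[C@H](OC(=O)c3ccc(Cl)cc3)C(C)(C)O[C@H]2CC[C@@]1(C)O` differs from compound 2 in one place (4-chlorophenyl in place of methyl on a carbonyl carbon), with 4-chlorophenyl in place of methyl on a carbonyl carbon, so that acetoxy becomes ((4-chlorophenyl)carbonyl)oxy.

Among the compounds with values here, with no measured step to lean on, the expectation is loose: a modest move toward stronger inhibition in this assay and no large jump. The expected size is the estimated step (a 2.4-fold lower number from compound 2 to compound 3 (0.38 log units; beyond the scatter)) and carries wide uncertainty. Compound 3 is expected at 20000 nM in a range from 6000 nM to 50000 nM as an estimate.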

Compound 3, half-maximal inhibitory concentration: 24100 nM
Compound 3: middle estimate off by 1.2-fold (0.08 log units), on the low side; the range from low to high includes it.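

In this assay, going by these compounds alone, the step of a 2.0-fold lower number from compound 2 to compound 3 (0.30 log units; within the scatter) is the first measured change, and it shows that the carbonyl carbon of the acetoxy group can carry 4-chlorophenyl in place of methyl with no shift beyond the scatter. The seven heavy atoms and aromatic ring that enter therefore yield no readable gain or loss at this place. Within the data shown here, compound 1 offers no step to compare with this one, and its entry is a limit, not a number: the limit of > 50000 nM in this assay, at which 1 of the 3 values shown sits.

From the compounds shown here alone, whether an unsubstituted phenyl, an amine or a longer chain on the same carbonyl carbon would move the number beyond the scatter stays open. So does whether a free hydroxyl in place of the whole ester would do so.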